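Aryl swap on the thiazole acetic acid series

The compounds below may be only part of what the source reports. "The series", "measured", "known", "first", "only" and "open" are said of these compounds alone.

Compound 2 `N#Cc1cc(-c2nc(C(c3ccc(F)cc3)c3ccc(F)cc3)sc2CC(=O)O)ccc1F` is measured in an in vitro functional assay on HEK285-7 cells for antagonist activity at prostaglandin D2 receptor 2 (Homo sapiens), read by BRET and beta-arrestin recruitment (a lower number here means a smaller maximal response, a higher number a larger maximal response), at 80%. Compound 3 `O=C(O)Cc1sc(C(c2ccccc2)c2ccccc2)nc1-c1ccccc1` gives 80%, which is level with compound 2 at the digits shown and within the scatter. Compound 1 `O=C(O)Cc1sc(Cc2ccccc2)nc1-c1ccc(Cl)cc1` gives 50%, a number under compound 2 and the only separation in this set that lies beyond the scatter. Compound 2 and compound 3 therefore sit together at the upper end of the three numbers.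

Compound 4 `O=C(O)Cc1sc(C(c2ccc(F)cc2)c2ccc(F)cc2)nc1-c1ccnc(F)c1` has not been measured in this assay. It differs from compound 2 in one place: 2-fluoropyridin-4-yl in place of 3-cyano-4-fluorophenyl on an aromatic carbon. Among the measured compounds shown here, no measured pair in the set isolates this change, so no direct step is available. The closest guide is that compound 3, carrying a different aryl group on the shared core, gives 80%, a number level with compound 2. On that basis the expected step of a number 5 percentage points lower from compound 2 to compound 4 (within the scatter) is small, and no direction beyond the scatter is predicted. Compound 4 is expected to reach 75%, with a likely range from 55% to 95%.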

Compound 4, largest response reached (reported as efficacy), in percent of the reference or control that the assay uses: 80%
Estimate against measurement, compound 4: 5 percentage points below; low and high end bracket the measured number.
By their numbers in this assay, from the lowest: compound 1; then compounds 2, 3 and 4 (each within the scatter of the next).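

Swapping 3-cyano-4-fluorophenyl for 2-fluoropyridin-4-yl on the aromatic carbon next to the ring nitrogen gives no change at the digits printed from compound 2 to compound 4 (within the scatter) in this assay and is the first step in the series that isolates this position. The maximal response therefore stays within the scatter when a six-membered aromatic ring of carbon only gives way to one with 1 hetero atom and the nitrile is lost. No supporting data bear on why the response holds across this change.

Still open, on these data alone, is whether this position keeps the response with a group lacking an aromatic ring, such as morpholine, or with plain pyridin-4-yl, which would separate the ring nitrogen from the fluorine. Compound 1 at 50% differs from the others in more than one place, so its gap cannot be assigned to this position.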